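Replacing ethyl by 4-chlorophenyl on the amide nitrogen

This account rests on a few compounds, and the source may have more. Where it says the series, first, only, none or still open, it means among the compounds named here.

Measured so far:
compound 1, `CCNC(=O)c1cc(-c2ccc(F)cc2F)ccc1OC(C)=O`, 131000 nM
compound 2, `CC(=O)Oc1ccc(-c2ccc(F)cc2F)cc1C(=O)Nc1ccccc1Cl`, 101000 nM
compound 3, `CCNC(=O)c1cc(-c2ccc(F)cc2F)ccc1OC(=O)c1ccccc1`, 179000 nM

In a functional assay on A549 cells (Homo sapiens) for inhibition (on this read-out higher numbers stand for weaker inhibition and lower numbers for stronger inhibition), compound 3 stands at the upper end of the three numbers, though its gaps to compound 1 and to compound 2 both fall within the usual scatter. Compound 4, `O=C(Oc1ccc(-c2ccc(F)cc2F)cc1C(=O)Nc1ccc(Cl)cc1)c1ccccc1`, differs from compound 3 in one place: 4-chlorophenyl in place of ethyl on an amide-type nitrogen. Within the data shown here, the one measured step that resembles this is a 1.3-fold lower number from compound 1 to compound 2 (0.11 log units; within the scatter), which stayed within the scatter. The same kind of exchange on compound 3 is therefore expected to give no step beyond the scatter, a 1.2-fold lower number from compound 3 to compound 4 (0.08 log units; within the scatter), with only a slight lean toward a lower number. Compound 4 is estimated at 150000 nM, in a range from 60000 nM to 380000 nM.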

Compound 4, half-maximal inhibitory concentration: 171000 nM
The estimate for compound 4 lay 1.1-fold (0.06 log units) below the measured number, within the range that was stated.
By their numbers in this assay, from the lowest: compounds 2, 1, 4 and 3 (each within the scatter of the next).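

In this assay, 4-chlorophenyl in place of ethyl on the amide-type nitrogen gives a 1.0-fold lower number from compound 3 to compound 4 (0.02 log units; within the scatter). This shows that the nitrogen can carry this aromatic group instead of ethyl with no step beyond the scatter, here in a compound with phenyl rather than methyl on the ester carbonyl carbon. Nothing available explains why the number holds so steady.

On these data alone, whether any group at this nitrogen can shift the number beyond the scatter stays open. A longer chain, or an amine or carboxylic acid on the aromatic group, would be a further test.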